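The source may hold more compounds than are shown below. What is called first, only, known or untested is meant among the compounds shown, and "the series" means these compounds.

Measured values in a functional assay on A2780 cells (Homo sapiens) for antiproliferative activity, read by fluorescence, with a stated time of 72 h; a lower number here means a stronger inhibitor, a higher number a weaker inhibitor:
Compound 1 `CN1CCC(C(=O)N2Cc3c(NC(=O)C4CCC4)n[nH]c3C2(C)C)CC1`: 140 nM
Compound 2 `CN1CCC(C(=O)N2Cc3c(NC(=O)c4cccs4)n[nH]c3C2(C)C)CC1`: 30 nM
Compound 3 `CN1CCC(C(=O)N2Cc3c(NC(=O)c4ccc(Cl)cc4)n[nH]c3C2(C)C)CC1`: 120 nM

Compound 3 stands second highest of the three numbers. Its nearest neighbour is compound 1, with a 1.2-fold lower number from compound 1 to compound 3 (0.07 log units; within the scatter), a gap that stays within the scatter, so the two cannot be ordered. The one clear separation is to compound 2: a 4.0-fold higher number from compound 2 to compound 3 (0.60 log units; beyond the scatter), a modest step beyond the scatter, matched by a 4.7-fold lower number from compound 1 to compound 2 (0.67 log units; beyond the scatter).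

The next compound, compound 4 `CN1CCC(C(=O)N2Cc3c(NC(=O)c4cc(F)cc(F)c4)n[nH]c3C2(C)C)CC1`, differs from compound 3 in one place: 3,5-difluorophenyl in place of 4-chlorophenyl on a carbonyl carbon.

Going by the values given here, no measured step replaces one substituted phenyl with another; the only step between two aromatic amides, a 4.0-fold higher number from compound 2 to compound 3 (0.60 log units; beyond the scatter), compares a thiophen-2-yl with a 4-chlorophenyl and was modest in size. The step from cyclobutyl to 4-chlorophenyl, a 1.2-fold lower number from compound 1 to compound 3 (0.07 log units; within the scatter), stayed within the scatter. The change from compound 3 to compound 4 keeps a six-membered aromatic ring of carbon only on the carbonyl carbon, so the best guide is a step of about the same size as those seen among the aromatic amides, with no direction indicated.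

The number for compound 4 in this assay is therefore expected close to that of compound 3, with a 1.1-fold higher number from compound 3 to compound 4 (0.03 log units; within the scatter), and the estimate is 130 nM, in the range 45 nM to 400 nM.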

Compound 4, half-maximal inhibitory concentration: 130 nM
Compound 4: middle estimate and measured number agree at the digits printed, within the range that was stated.
By their numbers in this assay, from the lowest: compound 2; then compounds 3, 4 and 1 (each within the scatter of the next).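

Swapping one substituted phenyl for another on the carbonyl carbon gives the first direct comparison of this kind in this assay, and the result is a 1.1-fold higher number from compound 3 to compound 4 (0.03 log units; within the scatter) with no order between the two, so 4-chlorophenyl and 3,5-difluorophenyl cannot be told apart here. The 3,5-difluorophenyl amide also cannot be ordered against the cyclobutyl amide, as shown by a 1.1-fold lower number from compound 1 to compound 4 (0.03 log units; within the scatter) within the scatter, which leaves three different groups at this place in one unresolved cluster. Thiophen-2-yl stays apart from that cluster, with a 4.3-fold higher number from compound 2 to compound 4 (0.64 log units; beyond the scatter) as a third modest step beyond the scatter, so the separation of compound 2 now holds against each of the other groups on the carbonyl carbon. Nothing available explains why thiophen-2-yl separates from the other three groups.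

As far as these compounds go, it remains open whether that separation belongs to thiophen-2-yl alone or extends to close relatives such as thiophen-3-yl, furan-2-yl or pyridin-3-yl. The compounds shown also leave open how this position responds to unsubstituted phenyl, or to a phenyl carrying an amine or a carboxylic acid.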